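The source may hold more compounds than are shown below. What is called first, only, known or untested is meant among the compounds shown, and "the series" means these compounds.

Compound 1, `COc1cc(-c2nnc(SCC(=O)c3ccccc3)n2N)cc(OC)c1OC`, gives 7800 nM in a functional assay on HepG2 cells (Homo sapiens) for antiproliferative activity, read by MTT assay, with a stated time of 48 h; a lower number here means a stronger inhibitor, a higher number a weaker inhibitor.
Compound 2, `COc1cc(-c2nnc(SCC(=O)c3ccc(C)cc3)n2N)cc(OC)c1OC`, gives only a limit, > 100000 nM.
Compound 3, `COc1cc(-c2nnc(SCC(=O)Nc3ccccc3C)n2N)cc(OC)c1OC`, gives only a limit, > 100000 nM.

Compound 3 thus stands at the limit of > 100000 nM in this assay, at which 2 of the 3 values shown sit, where no number was obtained. Compound 4, `COc1cc(-c2nnc(SCC(=O)NCc3ccc(C)cc3)n2N)cc(OC)c1OC`, differs from compound 3 in one place: 4-methylbenzyl in place of 2-methylphenyl on an amide-type nitrogen. For the measured compounds named here, no measured step touches this part of the molecule: an at least 12-fold higher number from compound 1 to compound 3 (1.10 log units; beyond the scatter) came with (2-methylphenyl)amino in place of phenyl on a carbonyl carbon, and an at least 12-fold higher number from compound 1 to compound 2 (1.10 log units; beyond the scatter) with methyl in place of hydrogen on an aromatic carbon, while a step that the two limits leave unreadable from compound 2 to compound 3 stays unreadable. Going by the values given here, both readable steps were large losses, and no step in this set shows a gain. Compound 4 is therefore expected to stay weak, with an expected step of a number no higher from compound 3 to compound 4 (the limit leaves the size open) that a limit would hide. The estimate for compound 4 is 100000 nM, between 20000 nM and 300000 nM.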

Compound 4, half-maximal inhibitory concentration: > 100000 nM
Compound 4 gave a limit, no number; the forecaster's own chance of this, stated with the estimate: 70%; the middle value lies on the limit itself.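

With (4-methylbenzyl)amino on the carbonyl carbon in place of phenyl, the change gives an at least 12-fold higher number from compound 1 to compound 4 (1.10 log units; beyond the scatter). A second group on the amide-type nitrogen therefore shares the loss seen with compound 3, so this loss is not confined to 2-methylphenyl. The steps among compounds 2, 3 and 4 cannot be read, because all three rest on the same limit: the limit of > 100000 nM in this assay, at which 3 of the 4 values shown sit.

From the compounds shown here alone, whether any group on that nitrogen can restore a measurable number stays open. A plain benzyl, an unsubstituted phenyl or a carboxylic acid on the ring could each answer this.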